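The source may hold more compounds than are shown below. What is called first, only, known or untested is meant among the compounds shown, and "the series" means these compounds.

The measured compounds:
compound 2, `Cc1ccc(-n2cc(CSC(=S)N3CCN(C(=O)OC(C)(C)C)CC3)nn2)cc1`, for which in a functional assay on ECa-109 cells (Homo sapiens) for inhibition, read by MTT assay, with a stated time of 72 h (on this read-out lower numbers stand for stronger inhibition and higher numbers for weaker inhibition), compound 2 gives 114000 nM;
compound 1, `O=C(OCc1ccccc1)N1CCN(C(=S)SCc2cn(Cc3ccc(Cl)cc3)nn2)CC1`, for which this assay reports only a limit, compound 1 giving > 128000 nM.

Going by the values given here, compound 2 therefore stands as the only measured number in this assay, and the single further value shown is a limit rather than a number. the limit of > 128000 nM in this assay, at which 1 of the 2 values shown sits, marks where that limit sits, and compound 1 is the one that reaches it. Compound 3, `CC(C)(C)OC(=O)N1CCN(C(=S)SCc2cn(Cc3ccc(Cl)cc3)nn2)CC1`, has not yet been measured in this assay. It differs from compound 2 by 4-chlorobenzyl in place of 4-methylphenyl on an aromatic nitrogen. Among the compounds with values here, no step between measured compounds exists here, so the size and direction of this change cannot be read from any measured pair. Both compounds already measured lie at the weak end of this assay, and compound 3 is expected to remain there too, the step from compound 2 to compound 3 being estimated as a 1.1-fold higher number from compound 2 to compound 3 (0.04 log units; within the scatter), which would not exceed the usual scatter. Compound 3 is accordingly estimated at 125000 nM, expected to fall between 60000 nM and 260000 nM, with a fair chance that this assay reports only a limit for it.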

Compound 3, half-maximal inhibitory concentration: > 128000 nM
Compound 3: no number, only a limit (the forecaster's own chance of this, stated with the estimate: 50%); middle value at least 1.0-fold (0.01 log units) from the limit.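

In this assay, from the compounds shown here alone, 4-chlorobenzyl in place of 4-methylphenyl on an aromatic nitrogen gives an at least 1.1-fold higher number from compound 2 to compound 3 (0.05 log units; that floor lies within the scatter), so this change at this position brings no gain in inhibition, although the true size of the step stays unknown. Compound 3 reports only a limit and not a number, and with it the series now reaches the end of the measurable range more often than not: the limit of > 128000 nM in this assay, at which 2 of the 3 values shown sit. The step from compound 1 to compound 3, tert-butyl in place of benzyl on an oxygen next to a carbonyl group, cannot be read, as both values are limits.

With only 4-methylphenyl and 4-chlorobenzyl shown on this aromatic nitrogen, it remains open whether any group there, such as a pyridyl ring or a phenyl ring carrying an amine, could bring the number into a clearly readable range. Going by these compounds, it is equally open whether replacing the tert-butyl or benzyl group on the oxygen with a chain ending in a carboxylic acid would change the picture in this assay.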